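A few compounds are considered here, and "the series" means these few. Any claim that something is new, unique, unknown or untested is made for them only; others in the source may bear on it.

In a functional assay on HCT-116 cells (Homo sapiens) for antiproliferative activity, read by MTT assay, with a stated time of 24 h (a higher number here means a weaker inhibitor, a lower number a stronger inhibitor), compound 1 (`COc1cc(OC)c(-c2coc3cc(OCc4ccc(F)cc4)ccc3c2=O)cc1OC`) gives 950 nM, compound 2 (`COc1cc(OC)c(-c2coc3cc(OCc4ccc(Br)cc4)ccc3c2=O)cc1OC`) gives 1980 nM and compound 3 (`COc1cc(OC)c(-c2coc3cc(OCc4cccc(F)c4)ccc3c2=O)cc1OC`) gives 4920 nM. Compound 3 thus has the highest number of the three and is the weakest inhibitor among them, with its steps to both others beyond the scatter. The change considered here leads from compound 3 to compound 4 (`COc1cc(OC)c(-c2coc3cc(OCc4cccc(C(F)(F)F)c4)ccc3c2=O)cc1OC`): trifluoromethyl in place of fluoro on an aromatic carbon. The group sits meta to a large group. The nearest measured precedent is the exchange of fluoro for bromo, a 2.1-fold higher number from compound 1 to compound 2 (0.32 log units; beyond the scatter), a modest step, although it was made elsewhere on the ring. The other two measured steps, a 5.2-fold higher number from compound 1 to compound 3 (0.71 log units; beyond the scatter) and a 2.5-fold higher number from compound 2 to compound 3 (0.40 log units; beyond the scatter), also differ in where the substituent sits, so they bear on the present change only loosely. Within the data shown here, no measured compound carries trifluoromethyl. No clear step beyond the scatter is therefore expected, only a possible slight drift towards a higher number. The estimated step, a 1.2-fold higher number from compound 3 to compound 4 (0.09 log units; within the scatter), is expected to stay within the scatter. Compound 4 is estimated at 6000 nM. Its expected range runs from 2200 nM to 16000 nM.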

Compound 4, half-maximal inhibitory concentration: 3400 nM
Compound 4: middle estimate off by 1.8-fold (0.25 log units), on the high side; low and high end bracket the measured number.
By their numbers in this assay, from the lowest: compound 1; then compounds 2, 4 and 3 (each within the scatter of the next, the first and the last beyond it).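

In this assay, the exchange of 3-fluorobenzyl for 3-(trifluoromethyl)benzyl gives a 1.4-fold lower number from compound 3 to compound 4 (0.16 log units; within the scatter), so at this place on the ring a group of four heavy atoms reads no differently from a single fluoro. Compound 4 also stays within the scatter of the 4-bromophenyl compound, with a 1.7-fold higher number from compound 2 to compound 4 (0.23 log units; within the scatter), yet a 3.6-fold higher number from compound 1 to compound 4 (0.55 log units; beyond the scatter) sets it clearly apart from the 4-fluorophenyl compound, so that compounds 2, 3 and 4 all lie beyond the scatter from compound 1. No measured evidence accounts for these numbers.

On these data alone, it remains open whether a nitrile or an amine in place of trifluoromethyl would give a step beyond the scatter from compound 3. Also open, as far as these compounds go, is whether trifluoromethyl, carried where compound 1 holds its fluoro, would keep the number of compound 1.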